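The source may report more compounds than this note shows. Statements on the series, on what has been measured and on what is new or still open speak of the compounds shown alone.

Compound 1, with the structure `CC(C)n1ncnc1-c1ccccc1NCC1=NCCN1`, has been tested in an in vitro functional assay on cells (Fibroblast) for agonist activity at Alpha-1B adrenergic receptor (Homo sapiens); a lower number here means that less compound is needed, a higher number that more compound is needed for the effect. In this assay compound 1 gives < 100000 nM, which is a limit of the assay and not a measured number. A second compound, compound 2 with the structure `CCn1cccc1-c1ccccc1NCC1=NCCN1`, has been tested in the same way. In this assay compound 2 gives < 100000 nM, again a limit rather than a number. So far, then, the limit of < 100000 nM in this assay, at which 2 of the 2 values shown sit, is all that the measurements show, and where compound 1 stands can only be given as that limit; no measured step between two compounds is at hand.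

Compound 3, with the structure `CCCCn1ncnc1-c1ccccc1NCC1=NCCN1`, has not yet been measured in this assay. It differs from compound 1 in one place: butyl in place of isopropyl on an aromatic nitrogen. With only limits to go on, a butyl in place of an isopropyl is expected to change the result little, and the step is estimated at a step that the limit leaves unreadable from compound 1 to compound 3, within the usual scatter. Compound 3 is therefore expected to give 30000 nM, with a range from 3000 nM to 100000 nM, and the assay may well once more report only a limit.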

Compound 3, half-maximal effective concentration: 200 nM
Beside the measured number, compound 3's estimate is 150-fold (2.18 log units) above it, outside the stated range (below it).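

In this assay compound 1 gives < 100000 nM, which is a limit of the assay and not a number. For the compounds shown here, no step between compound 1 and compound 3 can therefore be read. The compounds shown leave open how large the effect of butyl in place of isopropyl on the aromatic nitrogen actually is.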